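Compound 1 to compound 4: furan-2-yl exchanged for chloromethyl

The source may report more compounds than this note shows. Statements on the series, on what has been measured and on what is new or still open speak of the compounds shown alone.

compound 1 `CCOC(=O)c1csc2nc(-c3cccc(NC(=O)c4ccco4)c3)cn12`: > 20000 nM (a limit)
compound 2 `CCOC(=O)c1csc2nc(-c3ccc(NC(=O)Nc4ccc(Br)cn4)cc3)cn12`: 2440 nM
compound 3 `CCOC(=O)c1csc2nc(-c3ccc(NC(=O)Nc4ccccc4)cc3)cn12`: > 20000 nM (a limit)

In a functional assay on MV4-11 cells (Homo sapiens) for cytotoxicity, read by MTT assay, with a stated time of 72 h (a lower number here means a stronger inhibitor, a higher number a weaker inhibitor), compound 1 has no number, only a limit of > 20000 nM. The picture across the series is the limit of > 20000 nM in this assay, at which 2 of the 3 values shown sit.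

Compound 4 `CCOC(=O)c1csc2nc(-c3cccc(NC(=O)CCl)c3)cn12` departs from compound 1 at one place: chloromethyl in place of furan-2-yl on a carbonyl carbon. Within the data shown here, no measured step makes this exchange. Among the measured compounds shown here, the only step available is an at least 8.1-fold higher number from compound 2 to compound 3 (0.91 log units; beyond the scatter), with phenyl in place of 5-bromopyridin-2-yl on an amide-type nitrogen. It bears only loosely on this change, showing that one exchange in the group carried by the core can separate a measured value from the limit.

On that basis, a modest move towards a lower number in this assay is expected, although compound 4 may also stay at the limit. The expected size is an at least 1.6-fold lower number from compound 1 to compound 4 (0.22 log units; that floor lies within the scatter), a loosely estimated figure. For compound 4 the estimated value is 12000 nM, with an expected range of 3000 nM to 20000 nM.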

Compound 4, half-maximal inhibitory concentration: 17700 nM
Estimate against measurement, compound 4: 1.5-fold (0.17 log units) below; measured number inside the range.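

In this assay, chloromethyl on the carbonyl carbon gives this position its first measured number, with compound 4 at 17700 nM. Compound 1 has only a limit, > 20000 nM. The exchange reads as an at least 1.1-fold lower number from compound 1 to compound 4 (0.05 log units; that floor lies within the scatter); it is therefore not shown to move the number beyond the scatter, and the series remains largely at its limit: the limit of > 20000 nM in this assay, at which 2 of the 4 values shown sit.

As far as these compounds go, how far the true value of compound 1 lies from that of compound 4 stays open, so the full size of the exchange cannot be read. Also open, from the compounds shown here alone, is what an aminomethyl group, a carboxylic acid or a longer chain on the same carbonyl carbon would give in this assay.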